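This account rests on a few compounds, and the source may have more. Where it says the series, first, only, none or still open, it means among the compounds named here.

Compound 1 `CCOc1c(-c2cc(OC)c(OC)c(OC)c2)oc2ccccc2c1=O` is the reference point of this comparison. In a functional assay on PC-3 cells (Homo sapiens) for antiproliferative activity, read by WST assay, with a stated time of 3 days (on this read-out lower numbers stand for stronger inhibition and higher numbers for weaker inhibition), compound 1 gives 900 nM, the lowest of the numbers shown. Compound 2 `CCCOc1c(-c2cc(OC)c(OC)c(OC)c2)oc2ccccc2c1=O` gives 11800 nM in this assay. Compound 3 `CCCCCCCOc1c(-c2cc(OC)c(OC)c(OC)c2)oc2ccccc2c1=O` gives > 50000 nM in this assay, and this is a limit of the assay rather than a number (the limit of > 50000 nM in this assay, at which 1 of the 3 values shown sits). Compound 4 `CCCCN(CCCC)CCCCOc1c(-c2cc(OC)c(OC)c(OC)c2)oc2ccccc2c1=O` has not yet been measured; its difference from compound 1 is 2-(dibutylamino)ethyl in place of hydrogen on a saturated chain carbon, two bonds along the chain from an oxygen on an aromatic ring. Within the data shown here, two measured steps bear on this change, both at the same place on the chain: a 13-fold higher number from compound 1 to compound 2 (1.12 log units; beyond the scatter) and an at least 55-fold higher number from compound 1 to compound 3 (1.74 log units; beyond the scatter). Each extension of the chain at that carbon raised the number, and the longer extension raised it more; compound 4 carries an even larger group at that position. A large rise in this assay is therefore expected, a 28-fold higher number from compound 1 to compound 4 (1.44 log units; beyond the scatter). Compound 4 is estimated at 25000 nM, with a likely range from 4000 nM to 150000 nM, and the result may well come back only as a limit.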

Compound 4, half-maximal inhibitory concentration: 5300 nM
The estimate for compound 4 lay 4.7-fold (0.67 log units) above the measured number; the measured number falls inside the stated range.
By their numbers in this assay, from the lowest: compound 1; then compound 4; then compound 2. At a limit, above all of these: compound 3.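

At this carbon, a longer group does not simply mean a higher number in this assay: adding 2-(dibutylamino)ethyl still gives a 5.9-fold higher number from compound 1 to compound 4 (0.77 log units; beyond the scatter), yet the amine-bearing chain also shows a 2.2-fold lower number from compound 2 to compound 4 (0.35 log units; beyond the scatter), so compound 4 goes against the rise seen with chain length. Placing dibutylamino in place of propyl gives an at least 9.4-fold lower number from compound 3 to compound 4 (0.97 log units; beyond the scatter), which ties the lower number to the amine end of the chain and not to chain length alone. That step starts from compound 3, whose value is a limit of the assay and not a number: the limit of > 50000 nM in this assay, at which 1 of the 4 values shown sits.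

Going by these compounds, whether a smaller amine such as dimethylamino on the same chain would give a similarly low number stays open. So does whether a carboxylic acid at the chain end would behave like the amine.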